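The compounds below may be only part of what the source reports. "The series", "measured", "known", "first", "only" and "open" are said of these compounds alone.

Measured so far in an ADME assay on HFF cells (Homo sapiens) for cytotoxicity, with a stated time of 8 days; on this read-out lower numbers stand for higher toxicity in this test and higher numbers for lower toxicity in this test:
Compound 1 `CCCCSc1nc(N)nc2c1ncn2/C=C1/CC1(CO)CO` gives > 300000 nM, which is a limit of the assay rather than a number.
Compound 2 `CCCOc1nc(N)nc2c1ncn2/C=C1/CC1(CO)CO` gives > 300000 nM, again a limit of the assay.
Compound 3 `COCCOc1nc(N)nc2c1ncn2/C=C1/CC1(CO)CO` gives > 300000 nM, also a limit of the assay.

Compound 2 therefore stands at the limit, as do the other two compounds, and the step from compound 1 to compound 2 reads a step that the two limits leave unreadable from compound 1 to compound 2. The step from compound 1 to compound 3 reads a step that the two limits leave unreadable from compound 1 to compound 3, and the step from compound 2 to compound 3 reads a step that the two limits leave unreadable from compound 2 to compound 3. None of the three measured steps yields a readable size, since the limit of > 300000 nM in this assay, at which 3 of the 3 values shown sit, holds for every value in hand.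

Compound 4 `CCCCOc1nc(N)nc2c1ncn2/C=C1/CC1(CO)CO` differs from compound 2 by methyl in place of hydrogen on a saturated chain carbon, three bonds along the chain from an oxygen on an aromatic ring. The closest measured steps, the exchanges at the aromatic oxygen and the change on the chain between compound 2 and compound 3, left this assay at its limit throughout, so no step beyond the scatter is expected from compound 2 to compound 4 in this assay, and an unreadable step is the likely outcome. The expected step to compound 4 is therefore a number no higher from compound 2 to compound 4 (the limit leaves the size open), and compound 4 is estimated at 300000 nM, with a range from 150000 nM to 1000000 nM, most probably again reported as a limit.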

Compound 4, half-maximal cytotoxic concentration: > 300000 nM
Compound 4 ended at the assay's limit; the forecaster's own chance of this, stated with the estimate: 90%; the middle value sits exactly at the limit.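

In this assay compound 4 gives > 300000 nM, a limit of the assay. No step size can be read between compound 4 and compound 1, compound 2 or compound 3, as all four sit at that limit: the limit of > 300000 nM in this assay, at which 4 of the 4 values shown sit.

The compounds shown leave open whether butylsulfanyl, propoxy, 2-methoxyethoxy and butoxy differ at all in this assay.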